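The source may report more compounds than this note shows. Statements on the series, on what has been measured and on what is new or still open speak of the compounds shown alone.

Measured in an ADME assay on 184B5 cells (Homo sapiens) for cytotoxicity, read by MTT assay, with a stated time of 72 h; a lower number here means a stronger inhibitor of growth, a higher number a weaker inhibitor of growth:

Compound 1 `COc1ccc(OC(=O)Nc2ccc([Se]C#N)cc2)cc1`: 19200 nM
Compound 2 `CCCCOC(=O)Nc1ccc([Se]C#N)cc1`: 14500 nM
Compound 3 `Cc1ccc(OC(=O)Nc2ccc([Se][Se]c3ccc(NC(=O)Oc4ccc(C)cc4)cc3)cc2)cc1`: 7600 nM

Compound 2 gives neither the highest nor the lowest of the three numbers, and all three lie within the usual scatter of one another, so nothing separates them with confidence. Compound 4 `N#C[Se]c1ccc(NC(=O)OCc2ccccc2)cc1` is not yet measured in this assay. It differs from compound 2 in one place: phenyl in place of propyl on a saturated chain carbon bound to an oxygen next to a carbonyl group. Going by the values given here, no measured pair among the three compounds shows what such a swap does in this assay, so there is no guide to the size of the step. The step of a 1.2-fold lower number from compound 2 to compound 4 (0.08 log units; within the scatter) is expected to stay within the scatter, in either direction. Compound 4 is therefore expected to give about 12000 nM, with a range from 5000 nM to 30000 nM.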

Compound 4, concentration for total growth inhibition: 21900 nM
Compound 4: middle estimate off by 1.8-fold (0.26 log units), on the low side, within the range that was stated.
By their numbers in this assay, from the lowest: compounds 3, 2, 1 and 4 (each within the scatter of the next, the first and the last beyond it).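

In this assay, going by these compounds alone, phenyl in place of propyl on a saturated chain carbon bound to an oxygen next to a carbonyl group gives a 1.5-fold higher number from compound 2 to compound 4 (0.18 log units; within the scatter) and is the first one-place swap that can be read in this set. At this position, then, an aromatic ring can replace an open chain without a step beyond the scatter. Nothing in the data shown gives a reason for this result.

On these data alone, whether an amine, a carboxylic acid or a longer chain at this position would give a step beyond the scatter remains open. So does whether the same swap would behave alike on the core of compound 3.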